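This account rests on a few compounds, and the source may have more. Where it says the series, first, only, none or still open, it means among the compounds named here.

In a functional assay on A549 cells (Homo sapiens) for antiproliferative activity, read by MTT assay, with a stated time of 48 h (a lower number here means a stronger inhibitor, a higher number a weaker inhibitor), compound 1 `CN1C(=O)C2(C(C#N)=C(N)Oc3cc4oc(-c5ccccc5)cc(=O)c4c(O)c32)c2ccccc21` gives > 50000 nM, which is a limit of the assay and not a number. That places compound 1 at the limit of > 50000 nM in this assay, at which 1 of the 2 values shown sits. Among the compounds with values here, only one measured step starts from it: an at least 15-fold lower number from compound 1 to compound 2 (1.20 log units; beyond the scatter). This step replaces hydrogen with bromo on an aromatic carbon, and compound 2 `CN1C(=O)C2(C(C#N)=C(N)Oc3cc4oc(-c5ccccc5)cc(=O)c4c(O)c32)c2cc(Br)ccc21` gives 3150 nM.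

Compound 3 `N#CC1=C(N)Oc2cc3oc(-c4ccccc4)cc(=O)c3c(O)c2C12C(=O)Nc1ccccc12` differs from compound 1 somewhere else: hydrogen in place of methyl on an amide-type nitrogen in a ring. In words, hydrogen takes the place of methyl on an amide-type nitrogen in a ring. The large step to compound 2 an at least 15-fold lower number from compound 1 to compound 2 (1.20 log units; beyond the scatter) belongs to a different place on the shared core, so it offers no direct guide to the size of this change. Within the data shown here, no measured step covers this nitrogen. The expectation therefore stays close to the starting point set by compound 1 > 50000 nM, with no step beyond the scatter in this assay and a good chance that the assay again reports only a limit. The expected size of the change is an at least 1.1-fold lower number from compound 1 to compound 3 (0.04 log units; that floor lies within the scatter). The estimated value for compound 3 is 45000 nM, within an expected range of 12000 nM to 80000 nM.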

Compound 3, half-maximal inhibitory concentration: 37600 nM
Beside the measured number, compound 3's estimate is 1.2-fold (0.08 log units) above it; the range from low to high includes it.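

The change at this nitrogen now has its first measured reading, and in this assay the step is an at least 1.3-fold lower number from compound 1 to compound 3 (0.12 log units; that floor lies within the scatter). With hydrogen on the amide-type nitrogen, compound 3 gives a real number, 37600 nM, so this form of the shared core has a measured starting point for later comparisons. The step can only be read as a floor, since the value for compound 1 is a limit of the assay and not a number: the limit of > 50000 nM in this assay, at which 1 of the 3 values shown sits. Going by these compounds, its printed floor lies within the scatter, so a gain from swapping methyl for hydrogen cannot be claimed, and the true size of the step remains unknown.

The compounds shown leave open how this nitrogen would respond to something larger than methyl, such as an ethyl group, a longer chain or a chain ending in an amine. They also leave open whether bromo, which gave an at least 15-fold lower number from compound 1 to compound 2 (1.20 log units; beyond the scatter) when the nitrogen carried methyl, would have a similar effect when the nitrogen carries hydrogen.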